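Aryl exchange from compound 2 to compound 3

The compounds below may be only part of what the source reports. "The series", "measured", "known", "first", "only" and "open" are said of these compounds alone.

Compound 1 `COc1cc(Nc2ncnc3c(NC(=O)Nc4ccccc4Cl)cccc23)cc(OC)c1`: 356 nM
Compound 2 `COc1cc(Nc2ncnc3c(NC(=O)Nc4ccc5c(c4)OCCO5)cccc23)cc(OC)c1`: 2750 nM

Both values come from a functional assay on RT-112 cells (Homo sapiens) for antiproliferative activity, read by MTT assay, with a stated time of 72 h; a higher number here means a weaker inhibitor of growth, a lower number a stronger inhibitor of growth. Going by the values given here, compound 2 has the higher of the two numbers, and compound 1 is its only measured neighbour. Compound 3 `COc1cc(Nc2ncnc3c(NC(=O)Nc4cc(C)cc(C)c4)cccc23)cc(OC)c1` has not yet been measured. It differs from compound 2 as follows: 3,5-dimethylphenyl in place of 2,3-dihydro-1,4-benzodioxin-6-yl on an amide-type nitrogen. In short, 3,5-dimethylphenyl stands in place of 2,3-dihydro-1,4-benzodioxin-6-yl on an amide-type nitrogen.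

Among the compounds with values here, the only measured step that bears on this change is a 7.7-fold higher number from compound 1 to compound 2 (0.89 log units; beyond the scatter). That step is modest, and it introduced the group that now leaves. Within the data shown here, no measured compound carries 3,5-dimethylphenyl, so only a partial return towards compound 1 is expected. The expected step is a 2.8-fold lower number from compound 2 to compound 3 (0.44 log units; beyond the scatter). For compound 3 the estimated value is 1000 nM, with an expected range of 320 nM to 3000 nM.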

Compound 3, concentration for 50% growth inhibition: 10100 nM
For compound 3 the middle estimate is 10-fold (1.00 log units) below the measured one; measured number above the stated range.
By their numbers in this assay, from the lowest: compound 1; then compound 2; then compound 3.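

At this amide-type nitrogen, in this assay, replacing 2,3-dihydro-1,4-benzodioxin-6-yl does not by itself move the number back towards compound 1: 3,5-dimethylphenyl gives a 3.7-fold higher number from compound 2 to compound 3 (0.56 log units; beyond the scatter). Measured against 2-chlorophenyl, the same group gives a 28-fold higher number from compound 1 to compound 3 (1.45 log units; beyond the scatter), so all three aryl groups are separated beyond the scatter, with 2-chlorophenyl giving the lowest number and 3,5-dimethylphenyl the highest. No evidence is available to account for this order.

The compounds shown do not separate the effect of the two methyl groups from that of losing the oxygen-containing ring, since both differences arrive together in compound 3. Also open, from the compounds shown here alone, is how a simple phenyl, a 3-methylphenyl or a phenyl carrying an amine or a carboxylic acid would rank at this nitrogen.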